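Piperazine-capped chain on the propoxy-bearing amide series

A few compounds are considered here, and "the series" means these few. Any claim that something is new, unique, unknown or untested is made for them only; others in the source may bear on it.

For the measured compounds named here, compound 2 `CCCOc1ccc(C(=O)Nc2ccc(OC)cc2)cc1NC(=O)CC` carries the lowest of the two numbers so far in a toxicity assay on Huh-7.5 cells (Homo sapiens) for inhibition, read by MTT assay, with a stated time of 96 h (on this read-out higher numbers stand for lower toxicity in this test and lower numbers for higher toxicity in this test), where compound 2 gives 106000 nM. Its nearest neighbour is compound 1 `CCC(=O)Nc1cc(C(=O)Nc2ccc(OC)cc2)ccc1OC`, which in this assay gives 109000 nM; the step of a 1.0-fold lower number from compound 1 to compound 2 (0.01 log units; within the scatter) lies within the scatter, so the two compounds cannot be put in order.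

Compound 3 `CCC(=O)Nc1cc(C(=O)Nc2ccc(OC)cc2)ccc1OCCCN1CCN(C)CC1` is the next member and differs from compound 2 by 4-methylpiperazin-1-yl in place of hydrogen on a saturated chain carbon, three bonds along the chain from an oxygen on an aromatic ring. Going by the values given here, the only measured step, a 1.0-fold lower number from compound 1 to compound 2 (0.01 log units; within the scatter), also alters the saturated chain on the oxygen on the aromatic ring, by ethyl in place of hydrogen, and it left the number unchanged. Among the compounds with values here, that step is the sole guide here; the group entering in compound 3 is larger and of a different kind than anything yet measured, so the guide is weak.

On that basis no step beyond the scatter is expected, and the estimate for compound 3 in this assay is 90000 nM, with a range from 30000 nM to 200000 nM, which corresponds to an expected step of a 1.2-fold lower number from compound 2 to compound 3 (0.07 log units; within the scatter).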

Compound 3, half-maximal cytotoxic concentration: 127000 nM
For compound 3 the middle estimate is 1.4-fold (0.15 log units) below the measured one; the measured number falls inside the stated range.
By their numbers in this assay, from the lowest: compounds 2, 1 and 3 (each within the scatter of the next).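

In this assay, the step of a 1.2-fold higher number from compound 2 to compound 3 (0.08 log units; within the scatter) shows that the position on a saturated chain carbon, three bonds along the chain from an oxygen on an aromatic ring, can carry 4-methylpiperazin-1-yl, with its six-membered non-aromatic ring, without a shift beyond the scatter. Until now this chain had varied only by ethyl in place of hydrogen; the group entering here is far larger, at 7 heavy atoms, yet the three compounds still cannot be put in order. The same holds when the change is read from compound 1 as 2-(4-methylpiperazin-1-yl)ethyl in place of hydrogen on a saturated chain carbon bound to an oxygen on an aromatic ring, with a 1.2-fold higher number from compound 1 to compound 3 (0.07 log units; within the scatter), and no measurement at hand bears on this result.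

Open, on these data alone, is whether a primary amine or a carboxylic acid at the end of the same propyl chain would give a step beyond the scatter in this assay. Also open, as far as these compounds go, is whether morpholine in place of the 4-methylpiperazin-1-yl group, or a longer chain leading to it, would leave the number equally unmoved.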